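A few compounds are considered here, and "the series" means these few. Any claim that something is new, unique, unknown or untested is made for them only; others in the source may bear on it.

Measured so far:
- compound 1 `CC1=CC[C@@H]([C@@](C)(O)CCCC(C)(C)NC(=S)N/N=C\c2ccccc2[N+](=O)[O-])CC1`: 16200 nM
- compound 2 `CC1=CC[C@@H]([C@@](C)(O)CCCC(C)(C)NC(=S)N/N=C\c2cccc([N+](=O)[O-])c2)CC1`: 40800 nM

In a functional assay on OVCAR-3 cells (Homo sapiens) for cytotoxicity, read by sulforhodamine B assay (on this read-out higher numbers stand for weaker inhibition of growth and lower numbers for stronger inhibition of growth), compound 2 gives 40800 nM, the higher of the two numbers, so it is the weaker growth inhibitor of the pair. Compound 3 `CC1=CC[C@@H]([C@@](C)(O)CCCC(C)(C)NC(=S)N/N=C\c2ccc([N+](=O)[O-])cc2)CC1` differs from it by one change: 4-nitrophenyl in place of 3-nitrophenyl on a carbon with a double bond to nitrogen. Among the compounds with values here, only one measured step bears on this change: a 2.5-fold higher number from compound 1 to compound 2 (0.40 log units; beyond the scatter), a modest move that also swaps one nitrophenyl for another. A single step gives no firm direction for the next one, so a change of similar or smaller size is expected in this assay, possibly none beyond the scatter. The expected change is a 1.4-fold lower number from compound 2 to compound 3 (0.13 log units; within the scatter). For compound 3 the estimated value is 30000 nM, with an expected range from 12000 nM to 70000 nM.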

Compound 3, concentration for total growth inhibition: 88600 nM
For compound 3 the middle estimate is 3.0-fold (0.47 log units) below the measured one; the measured number lies above the stated range.
By their numbers in this assay, from the lowest: compound 1; then compound 2; then compound 3.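

In this assay the change to 4-nitrophenyl does not bring the number back towards compound 1: it gives a 2.2-fold higher number from compound 2 to compound 3 (0.34 log units; beyond the scatter) and, across the full span of the series, a 5.5-fold higher number from compound 1 to compound 3 (0.74 log units; beyond the scatter). The three isomers at this position now fall in one order, with 2-nitrophenyl lowest, 3-nitrophenyl in the middle and 4-nitrophenyl highest, every gap lying beyond the scatter, so compound 3 is the weakest growth inhibitor of the three. No available data account for this order.

Open, from the compounds shown here alone, is whether the order belongs to the nitro group itself or would also appear with another group on the phenyl ring, such as an amine or a carboxylic acid. An unsubstituted phenyl would set the baseline against which all three isomers could be read.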